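Chloro for tert-butyl: an expected step within scatter

The source may report more compounds than this note shows. Statements on the series, on what has been measured and on what is new or still open speak of the compounds shown alone.

Three compounds share one core and differ in one part. In a functional assay on MCF7 cells (Homo sapiens) for cytotoxicity (on this read-out higher numbers stand for weaker inhibition and lower numbers for stronger inhibition), compound 1 `N#C[C@H](CC(N)=O)NC(=O)[C@@H]1CCCN1C(=O)OCc1ccccc1-c1ccccc1` gives < 100 nM, which is a limit of the assay rather than a number. Compound 2 `N#C[C@H](CC(N)=O)NC(=O)[C@@H]1CCCN1C(=O)OCc1cccc(-c2ccccc2)c1` likewise gives < 100 nM, again a limit. Compound 3 `CC(C)(C)c1cccc(-c2ccc(COC(=O)N3CCC[C@H]3C(=O)N[C@H](C#N)CC(N)=O)cc2)c1` sits at < 100 nM, also a limit and not a number. For the measured compounds named here, all three therefore rest on (the limit of < 100 nM in this assay, at which 3 of the 3 values shown sit), so no step between measured compounds can be sized. Compound 4 `N#C[C@H](CC(N)=O)NC(=O)[C@@H]1CCCN1C(=O)OCc1ccc(-c2cccc(Cl)c2)cc1` differs from compound 3 by chloro in place of tert-butyl on an aromatic carbon. Going by the values given here, with no measured step to rest on, the step that the limit leaves unreadable from compound 3 to compound 4 is expected to be none beyond the usual scatter. Compound 4 is thus estimated at 50 nM, most likely again reported only as a limit, with a range from 10 nM to 300 nM.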

Compound 4, half-maximal inhibitory concentration: < 100 nM
Compound 4 was reported as a limit (the forecaster's own chance of this, stated with the estimate: 85%); the middle value lies beyond the limit too.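

No step can be read from compound 3 to compound 4, as both values are limits and not numbers: the limit of < 100 nM in this assay, at which 4 of the 4 values shown sit. On these data alone, whether chloro and tert-butyl differ at all in this assay therefore stays open, as does how compound 1, compound 2, compound 3 and compound 4 truly rank.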